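The source may hold more compounds than are shown below. What is called first, only, known or untested is meant among the compounds shown, and "the series" means these compounds.

Measured in a functional assay on MKN-45 cells (Homo sapiens) for cytotoxicity; on this read-out higher numbers stand for weaker inhibition and lower numbers for stronger inhibition:
compound 1 `COc1ccc(C(=O)Nc2cccc3c2N(S(=O)(=O)c2ccc(OC)cc2)CC3)cc1`: 1600 nM
compound 2 `COc1ccc(S(=O)(=O)N2CCc3cccc(NC(C)=O)c32)cc1`: 61 nM
compound 3 `COc1ccc(S(=O)(=O)N2CCc3cccc(NC(=O)N(C)c4ccccc4)c32)cc1`: > 10000 nM, a limit of the assay and not a number

Compound 1 stands highest of the two numbers shown; its nearest neighbour is compound 2, reached by a 26-fold lower number from compound 1 to compound 2 (1.42 log units; beyond the scatter). Compound 3 sits at the limit of > 10000 nM in this assay, at which 1 of the 3 values shown sits. The not yet measured compound 4 `COc1ccc(S(=O)(=O)N2CCc3cccc(N)c32)cc1` differs from compound 1 by hydrogen in place of (4-methoxyphenyl)carbonyl on a nitrogen on an aromatic ring.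

For the measured compounds named here, two measured steps bear on this change, both altering what sits on the carbonyl carbon of compound 1: a 26-fold lower number from compound 1 to compound 2 (1.42 log units; beyond the scatter), where the smaller methyl gives a large improvement, and an at least 6.2-fold higher number from compound 1 to compound 3 (0.79 log units; beyond the scatter), where the larger methyl(phenyl)amino worsens it; an at least 160-fold higher number from compound 2 to compound 3 (2.21 log units; beyond the scatter) points the same way. Across these three compounds, a smaller substituent on that nitrogen goes with a lower number. Compound 4 removes the whole (4-methoxyphenyl)carbonyl, so a lowering is expected, of a size placed between the measured steps because compound 2 gives 61 nM while still keeping a carbonyl that compound 4 lacks. The expected step is an 8.0-fold lower number from compound 1 to compound 4 (0.90 log units; beyond the scatter). Compound 4 is estimated at 200 nM, with a range from 40 nM to 2000 nM.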

Compound 4, half-maximal inhibitory concentration: 1200 nM
The estimate for compound 4 lay 6.0-fold (0.78 log units) below the measured number; the range from low to high includes it.
By their numbers in this assay, from the lowest: compound 2; then compounds 4 and 1 (each within the scatter of the next). At a limit, above all of these: compound 3.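

In this assay, hydrogen in place of the whole (4-methoxyphenyl)carbonyl gives a 1.3-fold lower number from compound 1 to compound 4 (0.12 log units; within the scatter), so on this nitrogen on an aromatic ring the two cannot be told apart, and compound 4 goes against the earlier link between a smaller substituent and a lower number. Among the groups shown, the low number depends on the acetyl itself and not merely on a small substituent: removing it gives a 20-fold higher number from compound 2 to compound 4 (1.29 log units; beyond the scatter). The methyl(phenyl)carbamoyl alone lies clearly on the unfavourable side of hydrogen, with an at least 8.3-fold lower number from compound 3 to compound 4 (0.92 log units; beyond the scatter), and that step starts from a limit of the assay and not a number: the limit of > 10000 nM in this assay, at which 1 of the 4 values shown sits.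

Acetyl is the only small acyl group shown, so it remains open whether formyl, propanoyl or methanesulfonyl on this nitrogen would match compound 2 at 61 nM. Also open, from the compounds shown here alone, is whether the carbonyl or the methyl of the acetyl carries the difference, a question that an ethyl on this nitrogen could help to settle.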